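A few compounds are considered here, and "the series" means these few. Any claim that something is new, unique, unknown or untested is made for them only; others in the source may bear on it.

Measured compounds:
compound 1 `CC(C)N(C(=S)SCc1oc2ccccc2c(=O)c1Cl)C(C)C`: 20000 nM
compound 2 `CC(C)N(C(=S)SCc1cc(=O)c2ccc(Cl)cc2o1)C(C)C`: 22700 nM

In a functional assay on HEp-2 cells (Homo sapiens) for antiproliferative activity, read by MTT assay, with a stated time of 72 h (a lower number here means a stronger inhibitor, a higher number a weaker inhibitor), compound 2 gives 22700 nM, and in this assay compound 1 gives 20000 nM. The two numbers lie within the usual scatter of each other, so compound 2 stands level with compound 1 rather than apart from it. Compound 3 `CC(C)N(C(=S)SCc1cc(=O)c2ccccc2o1)C(C)C` differs from compound 2 in one place: hydrogen in place of chloro on an aromatic carbon. Going by the values given here, no measured pair shows a step of this kind, so its size is not known from the data. The step from compound 2 to compound 3 is expected to be small, a 1.1-fold higher number from compound 2 to compound 3 (0.04 log units; within the scatter), with no direction beyond the scatter. Compound 3 is therefore estimated at 25000 nM, in a range from 10000 nM to 60000 nM.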

Compound 3, half-maximal inhibitory concentration: 13600 nM
The estimate for compound 3 lay 1.8-fold (0.26 log units) above the measured number, and the stated range covers the measured number.
By their numbers in this assay, from the lowest: compounds 3, 1 and 2 (each within the scatter of the next).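

In this assay hydrogen in place of chloro on an aromatic carbon gives a 1.7-fold lower number from compound 2 to compound 3 (0.22 log units; within the scatter) and a 1.5-fold lower number from compound 1 to compound 3 (0.17 log units; within the scatter) and both steps lie within the scatter. Compound 3 carries no chloro group at all yet stands level with compound 1 and compound 2, so at either carbon the chloro group is not required for the activity seen here. Nothing at hand explains this result. Still open, going by these compounds, is whether a different group on this aromatic carbon, such as an amine, a methoxy group or a carboxylic acid, would move the number beyond the scatter.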